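Methoxy addition on the anilide ring of compound 1

The source may hold more compounds than are shown below. What is called first, only, known or untested is meant among the compounds shown, and "the series" means these compounds.

Compound 1 `COc1ccc(C(=O)c2cc(OC)c(OC)c(OC)c2)cc1NC(=O)/C=C/c1ccc(OC)c(OC)c1` is the reference for this step. In a functional assay on COLO 205 cells (Homo sapiens) for cytotoxicity, read by MTT assay, with a stated time of 72 h (a lower number here means a stronger inhibitor, a higher number a weaker inhibitor), compound 1 gives 8200 nM, the lowest of the three numbers in hand, though the other two sit within the scatter of it. Compound 2 `C#CCOc1cccc(/C=C/C(=O)Nc2cc(C(=O)c3cc(OC)c(OC)c(OC)c3)ccc2OC)c1` gives 13400 nM and compound 3 `COc1ccc(C(=O)c2cc(OC)c(OC)c(OC)c2)cc1NC(=O)/C=C/c1ccc([N+](=O)[O-])cc1` gives 11400 nM. The measured steps, a 1.6-fold higher number from compound 1 to compound 2 (0.21 log units; within the scatter), a 1.4-fold higher number from compound 1 to compound 3 (0.14 log units; within the scatter) and a 1.2-fold lower number from compound 2 to compound 3 (0.07 log units; within the scatter), all change the aryl group on the double-bonded chain carbon; none touches the ring that carries the amide nitrogen and the carbonyl.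

Compound 4 `COc1ccc(/C=C/C(=O)Nc2cc(C(=O)c3cc(OC)c(OC)c(OC)c3)cc(OC)c2OC)cc1OC` differs from compound 1 by methoxy in place of hydrogen on an aromatic carbon, ortho to a methoxy group and meta to two large groups. For the measured compounds named here, no measured step covers a change on this ring, so nothing predicts a shift, and the changes that were measured all stayed within the scatter. No step beyond the scatter is therefore expected for a 1.0-fold higher number from compound 1 to compound 4 (0.02 log units; within the scatter). Compound 4 is expected to give about 8500 nM in this assay, estimated between 3000 nM and 25000 nM.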

Compound 4, half-maximal inhibitory concentration: 5700 nM
Compound 4: middle estimate off by 1.5-fold (0.17 log units), on the high side; the measured number falls inside the stated range.
By their numbers in this assay, from the lowest: compounds 4, 1, 3 and 2 (each within the scatter of the next, the first and the last beyond it).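

In this assay, for the compounds shown here, the step at this position (a 1.4-fold lower number from compound 1 to compound 4 (0.16 log units; within the scatter)) gives the first reading on the ring that carries the amide nitrogen and the carbonyl. A methoxy group can therefore stand on this aromatic carbon, ortho to a methoxy group and meta to two large groups, without moving the number beyond the scatter, as was also the case for the aryl changes on the double-bonded chain carbon. Nothing measured here speaks to the cause of this step.

As far as these compounds go, whether the same holds for other groups at this position stays open: an amine, a carboxylic acid or a longer alkoxy chain would each test it. Also open, from the compounds shown here alone, is whether this added methoxy behaves alike when 4-nitrophenyl or 3-(propargyloxy)phenyl replaces 3,4-dimethoxyphenyl.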